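The source may hold more compounds than are shown below. What is called first, only, known or untested is meant among the compounds shown, and "the series" means these compounds.

Three compounds share one core and differ in the acid-bearing side chain and its neighbouring substituent. Compound 1 `Cc1nn(-c2ccccn2)c2cc(-c3ccc(CC(C)(C)C(=O)O)cc3)ccc12` carries a branched acid; in a functional assay on cells for agonist activity at Free fatty acid receptor 1 (Mus musculus), read by FLIPR and calcium flux, with a stated time of 5 min (a higher number here means a larger maximal response, a lower number a smaller maximal response), compound 1 gives 18%. Compound 2 `COc1cc(CCC(=O)O)ccc1-c1ccc2c(C)nn(-c3ccccn3)c2c1` carries a 2-carboxyethyl group with a methoxy group on an aromatic carbon, and in this assay compound 2 gives 62%. Compound 3 `Cc1nn(-c2ccccn2)c2cc(-c3ccc(CCC(=O)O)cc3C#N)ccc12` keeps the 2-carboxyethyl group but has a cyano group in place of the methoxy; in this assay compound 3 gives 47%, which is the second highest of the three numbers, with compound 2 above it by a margin beyond the scatter and compound 1 below it by a larger margin, also beyond the scatter.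

Compound 4 `Cc1nn(-c2ccccn2)c2cc(-c3ccc(CCC(=O)O)cc3Cl)ccc12` differs from compound 3 by one change: chloro in place of cyano on an aromatic carbon. For the measured compounds named here, only one measured step bears on this place, namely the change that gave a number 15 percentage points lower from compound 2 to compound 3 (beyond the scatter), a modest step. Nothing measured involves chloro itself, so no direction is firmly indicated. A small step, within or just at the edge of the scatter, is expected in this assay from compound 3 to compound 4, estimated as a number 3 percentage points higher from compound 3 to compound 4 (within the scatter). Compound 4 is therefore expected to give about 50% in this assay, with a range from 30% to 70%.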

Compound 4, largest response reached (reported as efficacy), in percent of the reference or control that the assay uses: 102%
Compound 4: middle estimate off by 52 percentage points, on the low side; measured number outside the range, above it.
By their numbers in this assay, from the lowest: compound 1; then compound 3; then compound 2; then compound 4.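

In this assay a chloro group on this aromatic carbon, which sits ortho to a large group and meta to a 2-carboxyethyl group, gives a number 55 percentage points higher from compound 3 to compound 4 (beyond the scatter) and also a number 40 percentage points higher from compound 2 to compound 4 (beyond the scatter) with the rest of the structure unchanged. The earlier step alone, a number 15 percentage points lower from compound 2 to compound 3 (beyond the scatter) in the same assay, showed only a modest sensitivity to what sits here, whereas the new steps show that swapping this one substituent can move the maximal response far more, and that the smallest of the three groups by heavy atoms gives the highest number. Among these three groups the order from the lowest number upward is cyano, methoxy, chloro, and nothing available explains why chloro stands so far above the other two.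

Going by these compounds, whether fluoro, bromo, methyl or trifluoromethyl on this same carbon would match chloro or fall back towards cyano and methoxy stays open. Also open, on these data alone, is whether chloro would raise the response in the same way when the acid side chain is the branched one of compound 1 or a longer chain.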